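The source may hold more compounds than are shown below. What is called first, only, known or untested is meant among the compounds shown, and "the series" means these compounds.

In a functional assay on U-373MG ATCC cells (Homo sapiens) for inhibition, read by MTT assay, with a stated time of 72 h (on this read-out higher numbers stand for weaker inhibition and lower numbers for stronger inhibition), compound 1 `O=[N+]([O-])c1ccc(NC(=S)NCc2cccc(Cl)c2)cc1` gives 27000 nM and compound 2 `CC1(C)CC(NC(=S)Nc2cccc(C#N)c2)c2cc(F)ccc2O1` gives 30000 nM, so these two measured values lie within the usual scatter of each other. Compound 3 `COc1ccc(Cl)cc1CNC(=S)Nc1ccc([N+](=O)[O-])cc1` differs from compound 1 in one place: methoxy in place of hydrogen on an aromatic carbon, with methoxy in place of hydrogen on an aromatic carbon, ortho to a large group and para to a chloro group. Going by the values given here, no measured pair shows what this change does, so no step beyond the scatter is expected in this assay. The estimated step is a 1.1-fold lower number from compound 1 to compound 3 (0.03 log units; within the scatter). For compound 3 the expected value is 25000 nM, with an estimated range of 10000 nM to 60000 nM.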

Compound 3, half-maximal inhibitory concentration: 22000 nM
Compound 3: the middle estimate sits 1.1-fold (0.06 log units) above what was measured, within the range that was stated.
By their numbers in this assay, from the lowest: compounds 3, 1 and 2 (each within the scatter of the next).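

In this assay, methoxy in place of hydrogen, ortho to a large group and para to a chloro group, gives a 1.2-fold lower number from compound 1 to compound 3 (0.09 log units; within the scatter) and stays within the scatter. Going by these compounds alone, this position therefore takes a methoxy group with no readable change in the number, which the earlier compounds could not show. Nothing measured here offers an explanation for this result. On these data alone, whether an amine, a carboxylic acid or a longer chain such as butoxy at this position would also leave the number unchanged remains open.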